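The source may hold more compounds than are shown below. What is called first, only, known or untested is meant among the compounds shown, and "the series" means these compounds.

Measured so far in a functional assay on DU-145 cells (Homo sapiens) for cytotoxicity, read by sulforhodamine B assay, with a stated time of 2 days, tested at 100 uM; on this read-out lower numbers stand for less inhibition and higher numbers for more inhibition at the one concentration tested (going by the name of the read-out):
Compound 1 `CCCc1n[nH]c2c(=O)n(NC(=O)c3ccncc3)c(-c3cccc(OC)c3)nc12` gives 9.13% in this assay.
Compound 2 `COc1cccc(-c2nc3c(-c4ccc(Cl)cc4)n[nH]c3c(=O)n2NC(=O)c2ccncc2)c1` gives 54.4% in this assay.
Compound 3 `COc1cccc(-c2nc3c(-c4ccc(C5CCNCC5)cc4)n[nH]c3c(=O)n2NC(=O)c2ccncc2)c1` gives 37% in this assay.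

Compound 1 stands lowest of the three. Its nearest neighbour is reached by the step of a number 27.9 percentage points higher from compound 1 to compound 3 (beyond the scatter), its furthest by the step of a number 45.3 percentage points higher from compound 1 to compound 2 (beyond the scatter); between the two aryl-bearing compounds the step is a number 17.4 percentage points lower from compound 2 to compound 3 (beyond the scatter). All three steps change the group on the aromatic carbon of the shared core, from propyl to 4-chlorophenyl or to 4-(piperidin-4-yl)phenyl, or chloro to piperidin-4-yl on that aryl group.

Compound 4 `CCCc1n[nH]c2c(=O)n(NC(=O)c3ccccc3)c(-c3cccc(OC)c3)nc12` keeps the propyl group of compound 1 and differs only in the acyl group: phenyl in place of pyridin-4-yl on a carbonyl carbon. Among the compounds with values here, no measured step touches the carbonyl carbon or its ring, so no measured step bears on this change, and the propyl-bearing compound 1 is the only anchor. The change is therefore expected to give no step beyond the scatter in this assay, with the low reading of compound 1 carrying over. Compound 4 is estimated at 12%, between 0% and 32%, which is an expected step of a number 2.9 percentage points higher from compound 1 to compound 4 (within the scatter).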

Compound 4, a percentage reported as inhibition, at one concentration (the size of the read-out at that concentration, not a potency): 23.6%
Beside the measured number, compound 4's estimate is 11.6 percentage points below it; the range from low to high includes it.
By their numbers in this assay, from the lowest: compound 1; then compound 4; then compound 3; then compound 2.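

In this assay, the acyl group proves to matter: phenyl in place of pyridin-4-yl on a carbonyl carbon gives a number 14.5 percentage points higher from compound 1 to compound 4 (beyond the scatter). The earlier steps shown here all changed the group on the aromatic carbon of the shared core, so the reading now responds at a second place, here with the propyl group held fixed and with the ring nitrogen and its hydrogen-bond acceptor removed. Nothing available accounts for this step.

Within the data shown here, the benzoyl change is seen only with propyl on the aromatic carbon, and whether it carries over to the 4-chlorophenyl or 4-(piperidin-4-yl)phenyl compounds stays open. Also open, on these data alone, is how other groups on the carbonyl carbon, such as pyridin-3-yl, cyclohexyl or an aminomethyl group, stand in this assay.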